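Swapping 3-methoxybenzyl for 2-bromobenzyl on the sulfur

This account rests on a few compounds, and the source may have more. Where it says the series, first, only, none or still open, it means among the compounds named here.

In a functional assay on HepG2 cells (Homo sapiens) for antiproliferative activity, read by MTT assay, with a stated time of 24 h (a lower number here means a stronger inhibitor, a higher number a weaker inhibitor), compound 1 `Sc1nnc(-c2ccc3c(c2)OCCO3)n1-c1ccccc1` gives 60000 nM and compound 2 `COc1cccc(CSc2nnc(-c3ccc4c(c3)OCCO4)n2-c2ccccc2)c1` gives 35100 nM on the same read-out. The move between them is a 1.7-fold lower number from compound 1 to compound 2 (0.23 log units; within the scatter) and so leaves compound 2 with no standing apart from compound 1.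

Next comes compound 3 `Brc1ccccc1CSc1nnc(-c2ccc3c(c2)OCCO3)n1-c1ccccc1` with the change 2-bromophenyl in place of 3-methoxyphenyl on a saturated chain carbon bound to a sulfur in view: 2-bromophenyl in place of 3-methoxyphenyl on a saturated chain carbon bound to a sulfur. For the measured compounds named here, the only measured step bearing on it is a 1.7-fold lower number from compound 1 to compound 2 (0.23 log units; within the scatter) and that step put 3-methoxybenzyl in place of hydrogen on a sulfur. Going by the values given here, no measured pair exchanges one such group for another. On that evidence no step beyond the scatter is expected in this assay and no direction can be called. The expected step is a 1.1-fold lower number from compound 2 to compound 3 (0.04 log units; within the scatter) in size. For compound 3 the estimated value is 32000 nM with an expected range of 14000 nM to 70000 nM around it.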

Compound 3, half-maximal inhibitory concentration: 4730 nM
Compound 3: middle estimate off by 6.8-fold (0.83 log units), on the high side, and the stated range ends above it.
By their numbers in this assay, from the lowest: compound 3; then compounds 2 and 1 (each within the scatter of the next).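

In this assay, the group on the sulfur now separates compounds: 2-bromophenyl in place of 3-methoxyphenyl on a saturated chain carbon bound to a sulfur gives a 7.4-fold lower number from compound 2 to compound 3 (0.87 log units; beyond the scatter). Replacing the hydrogen on the sulfur also has no uniform outcome, since 2-bromobenzyl gives a 13-fold lower number from compound 1 to compound 3 (1.10 log units; beyond the scatter), whereas 3-methoxybenzyl gave a 1.7-fold lower number from compound 1 to compound 2 (0.23 log units; within the scatter). Nothing measured here accounts for the difference between these two groups.

The step from 3-methoxyphenyl to 2-bromophenyl alters both the substituent and its place on the phenyl ring, so the compounds shown do not separate these two changes. Also open, on these data alone, is whether a chlorobenzyl group or a longer chain such as phenethyl on the sulfur would keep the lower number seen with compound 3.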